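A few compounds are considered here, and "the series" means these few. Any claim that something is new, unique, unknown or untested is made for them only; others in the source may bear on it.

Working notes on the step from compound 2 to compound 3 in a functional assay on MCF7 cells (Homo sapiens) for antiproliferative activity; on this read-out lower numbers stand for stronger inhibition and higher numbers for weaker inhibition. Compound 1 `CC(=O)Oc1ccc2cc(-n3cc(-c4ccc(N(C)C)cc4)nn3)c(=O)oc2c1C` reaches only a limit: in this assay compound 1 gives > 100000 nM, which is a limit of the assay and not a number. For the measured compounds named here, compound 2 `Cc1c(O)ccc2cc(-n3cc(/C=C/c4ccccc4)nn3)c(=O)oc12` is the only compound with a measured number; in this assay compound 2 gives 33700 nM. The other entry, that of compound 1, is the limit (the limit of > 100000 nM in this assay, at which 1 of the 2 values shown sits). Compound 3 `CC(=O)Oc1ccc2cc(-n3cc(/C=C/c4ccccc4)nn3)c(=O)oc2c1C` differs from compound 2 by acetyl in place of hydrogen on an oxygen on an aromatic ring, hydroxy to acetoxy. Going by the values given here, no measured pair shows this single change; compound 1 carries the acetoxy group but differs elsewhere as well, so its limit and the number of compound 2 do not define the step. The expected step of a 1.6-fold higher number from compound 2 to compound 3 (0.21 log units; within the scatter) is small, toward weaker inhibition, close to the scatter. For compound 3 the estimate is 55000 nM, with a range from 15000 nM to 200000 nM.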

Compound 3, half-maximal inhibitory concentration: 28500 nM
Compound 3: middle estimate off by 1.9-fold (0.29 log units), on the high side; low and high end bracket the measured number.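

In this assay, acetyl in place of hydrogen on the oxygen on an aromatic ring gives a 1.2-fold lower number from compound 2 to compound 3 (0.07 log units; within the scatter), so hydroxy and acetoxy at this position cannot be told apart on this read-out. For the compounds shown here, with the acetoxy group held constant, 2-phenylethenyl in place of 4-(dimethylamino)phenyl on an aromatic carbon gives an at least 3.5-fold lower number from compound 1 to compound 3 (0.54 log units; beyond the scatter), which makes that place, and not the oxygen, the one where a change beyond the scatter shows in these compounds. The size of that step stays open, since compound 1 gives a limit of the assay and not a number: the limit of > 100000 nM in this assay, at which 1 of the 3 values shown sits.

On these data alone, whether a methyl ether, or a longer chain ending in an amine or a carboxylic acid, on this oxygen would move the number remains open. So does whether the hydroxy and acetoxy pair would also read alike with 4-(dimethylamino)phenyl in place of 2-phenylethenyl.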